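From Phenyl to Difluoromethyl on Compound 2

The source may hold more compounds than are shown below. What is called first, only, known or untested is meant among the compounds shown, and "the series" means these compounds.

In an ADME assay on microsomes from liver (Rattus norvegicus) for metabolic stability, with a stated time of 10 min, tested at 0.5 uM (a lower number here means that less of the compound is left, a higher number that more of the compound is left), compound 1 (`Cc1noc(C)c1[C@@H]1C[C@@](C)(c2sccc2Cl)N=C(N)S1`) gives 12% and compound 2 (`Cc1noc(-c2ccccc2)c1[C@@H]1C[C@@](C)(c2ccc(F)cc2F)N=C(N)S1`) gives 20% while compound 3 (`Cc1onc(-c2cccnc2)c1[C@@H]1C[C@@](C)(c2ccc(F)cc2F)N=C(N)S1`) gives 5% on the same read-out. Compound 2 thus stands within the scatter of compound 1 and clearly above compound 3, whose gap from compound 2 lies beyond the scatter. Compound 4 (`Cc1noc(C(F)F)c1[C@@H]1C[C@@](C)(c2ccc(F)cc2F)N=C(N)S1`) has not yet been measured. It differs from compound 2 by difluoromethyl in place of phenyl on an aromatic carbon at the ring atom next to the ring oxygen. The three measured compounds differ from one another in more than one place, so none of them isolates this change. Only a small upward movement in this assay is therefore expected, and probably none beyond the scatter. The expected change is a number 5 percentage points higher from compound 2 to compound 4 (within the scatter) on this tentative reading. For compound 4 the estimated value is 25% within a range of 10% to 45% remaining.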

Compound 4, percent of the compound remaining: 67%
The estimate for compound 4 lay 42 percentage points below the measured number, and the stated range ends below it.
By their numbers in this assay, from the lowest: compounds 3, 1 and 2 (each within the scatter of the next, the first and the last beyond it); then compound 4.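

In this assay, difluoromethyl in place of phenyl on an aromatic carbon, next to the ring oxygen, gives a number 47 percentage points higher from compound 2 to compound 4 (beyond the scatter). For the compounds shown here, this is the first comparison in the set that isolates a single place, and it shows that the group at this position can by itself move the read-out by a large amount, which the earlier compounds, differing from one another in more than one place, could not show. Nothing in the data shown accounts for the size of this step.

The compounds shown leave open whether the departure of phenyl or the arrival of difluoromethyl matters more, as one step does not separate the two. They also leave open how a trifluoromethyl group, an amine or a longer alkyl chain at this position would read.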